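A few compounds are considered here, and "the series" means these few. Any claim that something is new, unique, unknown or untested is made for them only; others in the source may bear on it.

Compound 1 `O=C(Nc1cc(C(F)(F)F)cc(C(F)(F)F)c1)C1CCc2ccccc2N1C(=O)c1ccccc1Cl` gives 1930 nM in a functional assay on NUGC-3 cells (Homo sapiens) for cytotoxicity, read by sulforhodamine B assay, with a stated time of 72 h; a higher number here means a weaker inhibitor of growth, a lower number a stronger inhibitor of growth.
Compound 2 `CCCC(=O)N1c2ccccc2CCC1C(=O)Nc1cc(C(F)(F)F)cc(C(F)(F)F)c1` gives 14400 nM in this assay.

Among the measured compounds shown here, of the two numbers in this assay, compound 2 has the higher one, so it is the weaker inhibitor of growth among the measured compounds; its only neighbour is compound 1, and the step of a 7.5-fold higher number from compound 1 to compound 2 (0.87 log units; beyond the scatter) separates them. Compound 3 `O=C(Nc1cc(C(F)(F)F)cc(C(F)(F)F)c1)C1CCc2ccccc2N1` differs from compound 2 in one place: hydrogen in place of propylcarbonyl on a nitrogen on an aromatic ring in a ring. For the measured compounds named here, the one measured step that bears on this position is a 7.5-fold higher number from compound 1 to compound 2 (0.87 log units; beyond the scatter), in which a smaller group on the carbonyl carbon went with a higher number. Going by the values given here, no measured step removes the carbonyl group from this nitrogen altogether, so the direction of the next step is uncertain; a further modest rise is expected. For compound 3 the estimate is 30000 nM, within 8000 nM to 100000 nM, corresponding to an expected step of a 2.1-fold higher number from compound 2 to compound 3 (0.32 log units; beyond the scatter).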

Compound 3, concentration for 50% growth inhibition: 8760 nM
Beside the measured number, compound 3's estimate is 3.4-fold (0.53 log units) above it; low and high end bracket the measured number.
By their numbers in this assay, from the lowest: compound 1; then compounds 3 and 2 (each within the scatter of the next).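

In this assay replacing the propylcarbonyl group on this nitrogen with hydrogen gives a 1.6-fold lower number from compound 2 to compound 3 (0.22 log units; within the scatter) and so makes no difference that can be read, which means the propylcarbonyl group shows no measurable gain over a bare nitrogen. Replacing the (2-chlorophenyl)carbonyl group with hydrogen gives a 4.5-fold higher number from compound 1 to compound 3 (0.66 log units; beyond the scatter) and does leave a difference, so among these three compounds only the (2-chlorophenyl)carbonyl group stands apart from hydrogen at this position. No measured evidence here explains this difference.

The compounds shown leave open whether the difference depends on the aromatic ring or on the chlorine, which a plain phenylcarbonyl group on this nitrogen would help to separate. Also open, on these data alone, is how a methyl group or a longer alkyl chain attached directly to this nitrogen, with no carbonyl, would compare.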